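Cytotoxicity notes on an aryl swap at a saturated ring carbon

The source may hold more compounds than are shown below. What is called first, only, known or untested is meant among the compounds shown, and "the series" means these compounds.

Measured compounds:
compound 1 `O=C1CC(c2ccc(F)cn2)CN1c1cnn2c1CN(C(=O)Nc1cc(F)c(F)c(F)c1)C(C1CC1)C2`: 38500 nM
compound 2 `C[C@H]1Cn2ncc(N3CC(c4ccccc4)CC3=O)c2CN1C(=S)Nc1cc(F)c(F)c(F)c1`: > 2000 nM

Among the measured compounds shown here, in a toxicity assay on HepG2 2.2.15 cells (Homo sapiens) for cytotoxicity, read by CellTiter-Glo (a lower number here means that less compound is tolerated, a higher number that more compound is tolerated), compound 1 gives 38500 nM, the only plain number in the set. For compound 2 the value > 2000 nM is a limit of the assay, not a number; (the limit of > 2000 nM in this assay, at which 1 of the 2 values shown sits). Compound 3 `O=C1CC(c2ncco2)CN1c1cnn2c1CN(C(=O)Nc1cc(F)c(F)c(F)c1)C(C1CC1)C2` differs from compound 1 in one place: 1,3-oxazol-2-yl in place of 5-fluoropyridin-2-yl on a saturated ring carbon. For the measured compounds named here, no step between two measured compounds exists here, so the expectation rests on compound 1 alone. In this assay the step of a 1.1-fold lower number from compound 1 to compound 3 (0.04 log units; within the scatter) is expected to stay within the usual scatter, in no particular direction. Compound 3 is estimated at 35000 nM, with a range from 12000 nM to 100000 nM.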

Compound 3, half-maximal cytotoxic concentration: > 200000 nM
Compound 3: a limit, no number; the forecaster's own chance of this, stated with the estimate: 30%; middle value at least 5.7-fold (0.75 log units) away from the limit.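

In this assay, 1,3-oxazol-2-yl in place of 5-fluoropyridin-2-yl on the saturated ring carbon gives an at least 5.1-fold higher number from compound 1 to compound 3 (0.71 log units; beyond the scatter). This position therefore affects how much compound is tolerated, which compound 1 and compound 2 could not show, as they differ in more than one place. For compound 3 the value is a limit of the assay, not a number: the limit of > 200000 nM in this assay, at which 1 of the 3 values shown sits.

The compounds shown do not separate the ring size, the ring oxygen and the loss of fluorine as contributors to this step. Going by these compounds, how an aminomethyl group or a carboxylic acid on this ring carbon would read remains open.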